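Replacing the formyl group of compound 1

A few compounds are considered here, and "the series" means these few. Any claim that something is new, unique, unknown or untested is made for them only; others in the source may bear on it.

Among the compounds with values here, in a functional assay on MCF7 cells (Homo sapiens) for antiproliferative activity, with a stated time of 5 days (a higher number here means a weaker inhibitor, a lower number a stronger inhibitor), compound 1 (`CCCCc1ccc2[nH]c(-c3ccc(OC)cc3)c(C=O)c2c1`) gives 22 nM, the lower of the two numbers measured so far, and compound 2 (`CCCCc1ccc2[nH]c(-c3ccc(C(F)(F)F)cc3)c(C=O)c2c1`) gives 66 nM. Compound 3 (`CCCCc1ccc2[nH]c(-c3ccc(OC)cc3)c(/C=N/O)c2c1`) keeps the methoxy group of compound 1 and changes the group on an aromatic carbon of the five-membered aromatic ring: a group of 3 heavy atoms (1 carbon, 1 nitrogen, 1 oxygen; no ring) in place of a group of 2 heavy atoms (1 carbon, 1 oxygen; no ring), on an aromatic carbon. Within the data shown here, no measured step touches the formyl group. The only one available, with trifluoromethyl in place of methoxy on an aromatic carbon, therefore serves as a rough gauge of size alone. That step, a 3.0-fold higher number from compound 1 to compound 2 (0.48 log units; beyond the scatter), is modest but beyond the scatter, so a change of similar or slightly smaller size toward a higher number is expected. The estimated step is a 2.3-fold higher number from compound 1 to compound 3 (0.36 log units; beyond the scatter). For compound 3, the expected value in this assay is 50 nM, with an estimated range of 12 nM to 220 nM.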

Compound 3, half-maximal inhibitory concentration: 212 nM
For compound 3 the middle estimate is 4.2-fold (0.63 log units) below the measured one, and the stated range covers the measured number.
By their numbers in this assay, from the lowest: compound 1; then compound 2; then compound 3.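

At this position on the five-membered aromatic ring, the formyl group proves sensitive to change: in this assay, the step is a 9.6-fold higher number from compound 1 to compound 3 (0.98 log units; beyond the scatter), and it is larger than the step at the methoxy group, a 3.0-fold higher number from compound 1 to compound 2 (0.48 log units; beyond the scatter). The entering group has 3 heavy atoms, 1 hydrogen-bond donor and 2 hydrogen-bond acceptors, whereas formyl has 2 heavy atoms, 0 hydrogen-bond donors and 1 hydrogen-bond acceptor, so this single change joins several differences. No measurement offered here explains the higher number of compound 3.

The three compounds cannot separate the added atoms from the added donor, and a nitrile, a carboxylic acid or an aminomethyl group at this carbon would test that further. On these data alone, it also remains open whether the same replacement would give a step of similar size with the trifluoromethyl group of compound 2 in place.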